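The source may hold more compounds than are shown below. What is called first, only, known or untested is meant among the compounds shown, and "the series" means these compounds.

Compound 1, `CC1CCN(C2CCN(S(=O)(=O)c3cn(C)c(=O)n(C)c3=O)CC2)CC1`, gives in an ADME assay on HCT-116 cells (Homo sapiens) for cytotoxicity, read by CellTiter-Glo, with a stated time of 72 h (a higher number here means a weaker inhibitor, a lower number a stronger inhibitor), the value > 10000 nM, a limit of the assay and not a number.
Compound 2, `Cc1noc(C)c1S(=O)(=O)N1CCC(N2CCC(C)CC2)CC1`, gives in this assay the value > 10000 nM, again a limit and not a number.

Compound 2 thus stands at the edge of what this assay reports, as does every value shown here (the limit of > 10000 nM in this assay, at which 2 of the 2 values shown sit). Compound 3, `CC1CCN(C2CCN(S(=O)(=O)c3ccc(F)cc3F)CC2)CC1`, differs from compound 2 in one place: 2,4-difluorophenyl in place of 3,5-dimethyl-1,2-oxazol-4-yl on a sulfonyl sulfur. Among the measured compounds shown here, no step between measured compounds exists, so compound 3 is expected to stay near the limit, with an expected step that the limit leaves unreadable from compound 2 to compound 3, no larger than the scatter. Compound 3 is therefore estimated at 15000 nM, between 5000 nM and 50000 nM.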

Compound 3, half-maximal inhibitory concentration: > 5000 nM
Compound 3: only a limit was reported; the forecaster's own chance of this, stated with the estimate: 80%; the middle value is on the limit's open side.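

In this assay, among the compounds shown here, compound 2 and compound 3 are both reported only as limits, so no step between them can be read. The compounds shown leave open what numerical value any of them would give, and whether 2,4-difluorophenyl in place of 3,5-dimethyl-1,2-oxazol-4-yl changes it.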